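Cyclobutyl on the Amine Nitrogen of Compound 2

The source may hold more compounds than are shown below. What is called first, only, known or untested is meant among the compounds shown, and "the series" means these compounds.

Two compounds built on a shared nucleoside core have been examined in an assay for inhibition of histone-lysine N-methyltransferase, H3 lysine-79 specific (Homo sapiens), with a stated time of 3 h, in the presence of a further agent that is not named here; a lower number here means a stronger inhibitor, a higher number a weaker inhibitor. Compound 1 `CC(C)N(CCCNC(=O)Nc1ccc(C(C)(C)C)cc1)[C@@H](C)[C@H]1O[C@@H](n2cnc3c(N)ncnc32)[C@H](O)[C@@H]1O` gives 6.34 nM. Compound 2 `C[C@H](NC1CC(CCc2nc3cc(C(C)(C)C)ccc3[nH]2)C1)[C@H]1O[C@@H](n2cnc3c(N)ncnc32)[C@H](O)[C@@H]1O` gives 690 nM, the higher of the two numbers, and the gap between compound 1 and compound 2 lies well beyond the scatter of the measurement. Compound 3 `C[C@@H]([C@H]1O[C@@H](n2cnc3c(N)ncnc32)[C@H](O)[C@@H]1O)N(C1CCC1)C1CC(CCc2nc3cc(C(C)(C)C)ccc3[nH]2)C1` is derived from compound 2 by a single change: cyclobutyl in place of hydrogen on an amine nitrogen. Within the data shown here, no measured pair in this set isolates that change, so the size of the step is open. The expectation, resting on the far lower number of compound 1 in this assay, is a marked move toward stronger inhibition, with the step from compound 2 to compound 3 estimated as a 20-fold lower number from compound 2 to compound 3 (1.29 log units; beyond the scatter). Compound 3 is accordingly expected to give about 35 nM, within a range of 6 nM to 200 nM.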

Compound 3, half-maximal inhibitory concentration: 1430 nM
Estimate against measurement, compound 3: 41-fold (1.61 log units) below; the whole stated range lies below it.
By their numbers in this assay, from the lowest: compound 1; then compound 2; then compound 3.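

In this assay, among these compounds, the exchange of hydrogen for cyclobutyl on the amine nitrogen comes with a 2.1-fold higher number from compound 2 to compound 3 (0.32 log units; beyond the scatter) and is the first measured change at this position. It shows that a substituent on this nitrogen, whose other neighbours are a saturated chain carbon and a saturated ring carbon, is tolerated with only a modest loss, and that cyclobutyl here brings no gain in inhibition. Nothing at hand accounts for the direction or the size of this step.

From the compounds shown here alone, how a methyl or an ethyl group on the same nitrogen would compare with hydrogen and cyclobutyl remains open, as does a longer chain ending in a hydroxyl group. Also open, going by these compounds, is whether cyclobutyl would have a similar effect in the setting of compound 1, where isopropyl occupies the amine nitrogen.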